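The compounds below may be only part of what the source reports. "The series", "measured", "known", "first", "only" and "open" are said of these compounds alone.

Measured so far:
Compound 1 `CCN(CC)C(=O)Cn1c(=O)c(-c2ccc(OC)cc2)cc2c(OC)cc(OC)cc21` — in a functional assay on A-427 cells (Homo sapiens) for cytotoxicity, read by colorimetric assay and MTT assay (on this read-out higher numbers stand for weaker inhibition and lower numbers for stronger inhibition), compound 1 gives 10000 nM
Compound 2 `COc1ccc(-c2cc3c(OC)cc(OC)cc3n(CC#N)c2=O)cc1` — in this assay compound 2 gives 10000 nM

Compound 2 stands level with compound 1 in this assay: the step of no change at the digits printed from compound 1 to compound 2 (within the scatter) lies within the scatter of repeated measurements, so the two cannot be ordered. Compound 3 `COc1ccc(-c2cc3c(OC)cc(OC)cc3n(CCC#N)c2=O)cc1` differs from compound 2 by cyanomethyl in place of cyano on a saturated chain carbon bound to an aromatic nitrogen. Within the data shown here, the one measured step that bears on this change is the one at the same place, from compound 1 to compound 2, where the group on the saturated chain carbon bound to an aromatic nitrogen was exchanged without a change at the digits recorded. Because no change at the digits printed from compound 1 to compound 2 (within the scatter) showed nothing beyond the scatter, the step from compound 2 to compound 3, a lengthening of that chain by one carbon, is expected to be flat as well: no change at the digits printed from compound 2 to compound 3 (within the scatter). Compound 3 is therefore estimated at 10000 nM in this assay, with a range of 5000 nM to 20000 nM.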

Compound 3, half-maximal inhibitory concentration: 10000 nM
Compound 3: the middle estimate sits on the measured number at the digits printed; measured number inside the range.
By their numbers in this assay, from the lowest: compounds 1, 2 and 3 (each within the scatter of the next).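

In this assay, the nitrile group now stands on two chain lengths at this position, and cyanomethyl in place of cyano reads (no change at the digits printed from compound 2 to compound 3 (within the scatter)). Against the amide of the first compound, cyanomethyl in place of diethylcarbamoyl reads (no change at the digits printed from compound 1 to compound 3 (within the scatter)), so three groups on the saturated chain carbon bound to an aromatic nitrogen now share one printed level, where earlier there were two. No measurement is available that could explain this shared level.

Open, on these data alone, is whether any group at this position separates from that level, for instance a primary amine, a carboxylic acid or a longer chain ending in a nitrile. Also open, as far as these compounds go, is whether the same groups would read alike on a core carrying other substituents.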